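An oxetane in place of a tertiary alcohol

This account rests on a few compounds, and the source may have more. Where it says the series, first, only, none or still open, it means among the compounds named here.

The three measured compounds share one core, seen in compound 1 `CC(C)(C)Nc1c(-c2ccccn2)nc2c(OCc3ccccc3)cccn12`, compound 2 `Cc1ccc2nc(-c3ccccn3)c(Nc3ccc4c(c3)OCCO4)n2c1` and compound 3 `CC(C)(O)CNc1c(-c2ccccn2)nc2ccccn12`. In an ADME assay on THP-1 cells (Homo sapiens) for cytotoxicity (a lower number here means that less compound is tolerated, a higher number that more compound is tolerated), compound 2 gives 16000 nM. Compound 1 reaches only the limit of the assay in this assay, reported as > 50000 nM. Compound 3 likewise reaches only the limit in this assay, reported as > 50000 nM. Compound 3 thus stands at the limit of > 50000 nM in this assay, at which 2 of the 3 values shown sit, with no number of its own; of the three, only compound 2 falls inside the measured range.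

Compound 4 `c1ccc(-c2nc3ccccn3c2NCC2CCO2)nc1` differs from compound 3 in one place: oxetan-2-yl in place of 1-hydroxy-1-methylethyl on a saturated chain carbon bound to a nitrogen on an aromatic ring. Within the data shown here, no pair of measured compounds in this set differs in a single place, so there is no measured step to lean on for this change. Since compound 3 sits at the limit, the expectation for compound 4 in this assay is that it again reaches the limit rather than a number inside the range, an expected step of a number no higher from compound 3 to compound 4 (the limit leaves the size open) that amounts to none beyond the scatter. Compound 4 is therefore expected to give about 50000 nM, in a range from 20000 nM to 100000 nM.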

Compound 4, half-maximal cytotoxic concentration: > 50000 nM
Compound 4 gave a limit, no number (the forecaster's own chance of this, stated with the estimate: 70%); the middle value sits exactly at the limit.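

Compound 3 and compound 4 both reach only a limit in this assay, so no step can be read from one to the other: the limit of > 50000 nM in this assay, at which 3 of the 4 values shown sit.

The compounds shown leave open whether oxetan-2-yl in place of 1-hydroxy-1-methylethyl changes the read-out in this assay at all, and in which direction any such change would run.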